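Methoxy Added to the Fluorophenyl Ring of Compound 1

A few compounds are considered here, and "the series" means these few. Any claim that something is new, unique, unknown or untested is made for them only; others in the source may bear on it.

Measured so far:
compound 1 `O=C(NCCCCc1ccccc1)c1cccc(C2SCC(=O)N2c2cccc(F)c2)c1` — 63%
compound 2 `O=C(NCCCCc1ccccc1)c1cccc(C2OCC(=O)N2c2cccc(F)c2)c1` — 0%
compound 3 `CCOc1ccccc1N1C(=O)C(C)SC1c1cccc(C(=O)NCCCCc2ccccc2)c1` — 53%

In a functional assay on 143B cells (Homo sapiens) for inhibition, read by CCK-8 assay, with a stated time of 72 h, tested at 1 uM (a lower number here means less inhibition, a higher number more inhibition at the concentration tested (going by the name of the read-out)), compound 1 gives the highest of the three numbers. Compound 3 sits within the scatter of it, so the two cannot be told apart; compound 2, where oxygen replaces sulfur in the core, lies far below, beyond the scatter.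

Compound 4 `COc1ccc(F)cc1N1C(=O)CSC1c1cccc(C(=O)NCCCCc2ccccc2)c1` is the next step from compound 1. The change is methoxy in place of hydrogen on an aromatic carbon. For the measured compounds named here, no measured pair shows this exact change, but compound 3 carries an ethoxy group on the same ring and gives 53%, close to compound 1. The step is therefore expected to be small, probably none beyond the scatter, perhaps slightly downward: a number 8 percentage points lower from compound 1 to compound 4 (within the scatter). Compound 4 is estimated at 55%, with a range from 35% to 75%.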

Compound 4, a percentage reported as inhibition, at one concentration (the size of the read-out at that concentration, not a potency): 62%
For compound 4 the middle estimate is 7 percentage points below the measured one; the measured number falls inside the stated range.
By their numbers in this assay, from the lowest: compound 2; then compounds 3, 4 and 1 (each within the scatter of the next).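

In this assay the change from 3-fluorophenyl to 5-fluoro-2-methoxyphenyl gives a number 1 percentage points lower from compound 1 to compound 4 (within the scatter) and so shows that methoxy can take the place of hydrogen on this aromatic carbon, ortho to a large group and para to the fluoro group, without a step that stands out from the scatter. The earlier compounds shown here held no pair isolating this single change. No measurement here offers a reason for this result. Going by these compounds, whether an amine or a carboxylic acid on this same carbon would leave the number as little moved remains open. So does the effect of methoxy on a ring without the fluoro group.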